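The compounds below may be only part of what the source reports. "The series", "measured", "known", "first", "only" and "open" are said of these compounds alone.

Of the compounds shown here, three sharing one core have been tested in an ADME assay on microsomes from liver (Homo sapiens) for metabolic stability, with a stated time of 30 min; a higher number here means that more of the compound is left, a lower number that less of the compound is left. Compound 1 `NC(=O)c1sc2nccc(OC3CCCCC3)c2c1N` gives 1%. Compound 3 `NC(=O)c1sc2nccc(Oc3ccc(CCO)cc3)c2c1N` gives 93%. Compound 2 `Cc1cc(Oc2ccc(CCCC(=O)N(C)C)cc2F)c2c(N)c(C(N)=O)sc2n1` gives 60%, the second highest of the three numbers; its nearest neighbour is compound 3, whose value is higher by more than the usual scatter, and its furthest is compound 1, whose value is lower by more than the scatter. Compound 4 `Cc1cc(Oc2ccc(CCCC(=O)N(C)C)cc2Cl)c2c(N)c(C(N)=O)sc2n1` differs from compound 2 in one place: chloro in place of fluoro on an aromatic carbon. For the measured compounds named here, no step between two measured compounds of this kind exists to guide the change. The step in this assay is therefore expected to be small, without a direction beyond the scatter, as a number 2 percentage points lower from compound 2 to compound 4 (within the scatter). Compound 4 is estimated at 58%, within a range from 38% to 78%.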

Compound 4, percent of the compound remaining in the Homo sapiens assay: 25%
Beside the measured number, compound 4's estimate is 33 percentage points above it, outside the stated range (below it).
By their numbers in the Homo sapiens assay, from the lowest: compound 1; then compound 4; then compound 2; then compound 3.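

In the Homo sapiens assay, chloro in place of fluoro on this aromatic carbon, ortho to a large group, gives a number 35 percentage points lower from compound 2 to compound 4 (beyond the scatter) and so shows that one atom at this position can matter greatly. In a physicochemical assay for solubility, at pH 6.8 (a lower number here means a less soluble compound, a higher number a more soluble compound), compound 2 gives 0.3 ug/mL and compound 4 gives 0.2 ug/mL and these numbers lie within the usual scatter of each other. Nothing measured here gives a reason for the step in compound survival.

From the compounds shown here alone, whether hydrogen, methyl or bromo at this position would track fluoro or chloro remains open. So does whether the same exchange would act alike on the core of compound 3.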